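The compounds below may be only part of what the source reports. "The series", "measured", "known", "first", "only" and "open" are said of these compounds alone.

Of the compounds shown here, two sharing one core have been measured so far. Compound 1 `CCCCCCCn1ccc2cc(/C(C)=C/C(=O)Nc3ccccc3OCCCC(=O)O)ccc21` carries a heptyl group on the aromatic nitrogen of its core, and in an assay on Prostate gland for inhibition of steroid 5-alpha-reductase (Rattus norvegicus) (on this read-out lower numbers stand for stronger inhibition and higher numbers for weaker inhibition), compound 1 gives 120 nM. Compound 2 `C/C(=C\C(=O)Nc1ccccc1OCCCC(=O)O)c1ccc2c(ccn2CC(C)C)c1` differs from it by isopropyl in place of hexyl on a saturated chain carbon bound to an aromatic nitrogen, and in this assay compound 2 gives 160 nM. The step of a 1.3-fold higher number from compound 1 to compound 2 (0.12 log units; within the scatter) leaves compound 1 with the lower of the two numbers, but since that step lies within the scatter the two compounds cannot be told apart.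

Compound 3 `CCCCC(CCCC)n1ccc2cc(/C(C)=C/C(=O)Nc3ccccc3OCCCC(=O)O)ccc21` has not yet been measured. It differs from compound 1 as follows: 1-butylpentyl in place of heptyl on an aromatic nitrogen. Going by the values given here, the only measured step touching this place, a 1.3-fold higher number from compound 1 to compound 2 (0.12 log units; within the scatter), exchanged the chain on the aromatic nitrogen and moved the number no further than the scatter. On that basis the step of a 1.1-fold higher number from compound 1 to compound 3 (0.03 log units; within the scatter) is expected to stay within the scatter too, with no clear direction. Compound 3 is therefore estimated at 130 nM, in a range from 60 nM to 300 nM.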

Compound 3, half-maximal inhibitory concentration: 21 nM
Compound 3: the middle estimate sits 6.2-fold (0.79 log units) above what was measured, and the stated range ends above it.
By their numbers in this assay, from the lowest: compound 3; then compounds 1 and 2 (each within the scatter of the next).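

In this assay the exchange of heptyl for 1-butylpentyl gives a 5.7-fold lower number from compound 1 to compound 3 (0.76 log units; beyond the scatter) and the exchange of isobutyl for the same group gives a 7.6-fold lower number from compound 2 to compound 3 (0.88 log units; beyond the scatter) so the place on the aromatic nitrogen, which seemed indifferent to its chain when only the first two compounds were known, clearly responds to the group it carries. Heptyl and isobutyl remain within the scatter of each other, so not every exchange at this place moves the number, and among the three groups shown only 1-butylpentyl stands apart. No independent measurement is available to explain why this group gives the lower number.

The three groups do not show whether the lower number goes with the carbon count of 1-butylpentyl or with its shape, and a straight nonyl chain, which has the same number of carbons, would help separate the two. Going by these compounds, it also remains open whether a still larger group such as 1-pentylhexyl would lower the number further, or whether a cyclohexyl ring could take the place of 1-butylpentyl.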